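Iodo to hydrogen in a series at its limit

This account rests on a few compounds, and the source may have more. Where it says the series, first, only, none or still open, it means among the compounds named here.

Compound 1 `Cn1c(=O)[nH]c2c(ncn2C2O[C@H](CI)[C@@H](O)[C@H]2O)c1=N`: > 100 mg/kg (a limit, not a number)
Compound 2 `Cn1c(=N)c2ncn3c2n(c1=O)C[C@H]1OC3[C@H](O)[C@@H]1O`: > 100 mg/kg (a limit, not a number)

In a functional assay on the whole organism with Mus musculus as the target (on this read-out lower numbers stand for an effect already at smaller amounts and higher numbers for an effect only at larger amounts of compound), compound 1 gives > 100 mg/kg, which is a limit and not a number. Among the measured compounds shown here, compound 2 stands at a limit as well, so the series so far offers only (the limit of > 100 mg/kg in this assay, at which 2 of the 2 values shown sit). For the measured compounds named here, no measured step is available to size a structural change.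

Compound 3 `C[C@H]1OC(n2cnc3c(=N)n(C)c(=O)[nH]c32)[C@H](O)[C@@H]1O` carries hydrogen in place of iodo on a saturated chain carbon bound to a saturated ring carbon, iodomethyl to methyl (hydrogen in place of iodo on a saturated chain carbon bound to a saturated ring carbon). With no number to start from, no shift beyond the scatter is expected in this assay, and a further limit is the likeliest report. The expected step is a step that the limit leaves unreadable from compound 1 to compound 3. For compound 3 the estimated value is 120 mg/kg. The expected range for compound 3 runs from 40 mg/kg to 300 mg/kg.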

Compound 3, dose for half-maximal effect: > 100 mg/kg
Compound 3: only a limit was reported; the forecaster's own chance of this, stated with the estimate: 65%; the middle value lies beyond the limit too.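

Compound 1 and compound 3 both sit at a limit in this assay, so the change from iodomethyl to methyl yields no readable step. The compounds shown leave open whether any dose gives a half-maximal effect, since all values are limits: the limit of > 100 mg/kg in this assay, at which 3 of the 3 values shown sit.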